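The compounds below may be only part of what the source reports. "The series", "measured", "known", "first", "only" and "open" are said of these compounds alone.

Measured so far in an assay on CHO cells for inhibition of Glucagon receptor (Homo sapiens), tested at 20 uM; a lower number here means less inhibition, a higher number more inhibition at the concentration tested (going by the name of the read-out):

Compound 1, `CCCCCc1c(C(C)C)nc(C(C)C)c(CO)c1-c1ccccc1NC(C)=O`: 13%
Compound 2, `CCCCCc1c(C(C)C)nc(C(C)C)c(CO)c1-c1ccc(CC)cc1`: 42%
Compound 3, `CCCCCc1c(C(C)C)nc(C(C)C)c(CO)c1-c1ccc(C(C)C)cc1`: 34%

Compound 3 stands second highest of the three numbers. Its nearest neighbour is compound 2, which gives 42% in this assay, a difference that lies within the scatter; the furthest is compound 1, which gives 13%, a gap beyond the scatter.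

Compound 4 is `CCCCCc1c(C(C)C)nc(C(C)C)c(CO)c1-c1ccccc1OC`, not yet measured. From compound 3 it differs in one place: 2-methoxyphenyl in place of 4-isopropylphenyl on an aromatic carbon.

Among the compounds with values here, only one measured step bears on this change, and only loosely: a number 8 percentage points lower from compound 2 to compound 3 (within the scatter), a swap of one para-substituent for another on the same phenyl ring. Within the data shown here, no measured step swaps a para-substituent for an ortho-methoxy group. Compound 1 carries an ortho-acetamido group on the same phenyl ring and gives the lowest number of the three, but it differs from compound 3 in more than one place, so its value shows only that an ortho-substituted phenyl has so far coincided with weaker inhibition.

On this basis a downward step of moderate size is expected for compound 4, roughly a number 12 percentage points lower from compound 3 to compound 4 (beyond the scatter), with wide uncertainty. Compound 4 is therefore estimated at 22%, with a range from 8% to 38%.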

Compound 4, a percentage reported as inhibition, at one concentration (the size of the read-out at that concentration, not a potency): 27%
For compound 4 the middle estimate is 5 percentage points below the measured one; the range from low to high includes it.
By their numbers in this assay, from the lowest: compound 1; then compounds 4, 3 and 2 (each within the scatter of the next, the first and the last beyond it).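

In this assay, within the data shown here, at the aromatic carbon opposite the ring nitrogen, 2-methoxyphenyl in place of 4-isopropylphenyl gives a number 7 percentage points lower from compound 3 to compound 4 (within the scatter) and so cannot be told apart from no change, while 2-methoxyphenyl in place of 4-ethylphenyl gives a number 15 percentage points lower from compound 2 to compound 4 (beyond the scatter) as the first step at this position beyond the scatter. The two 4-substituted phenyl compounds therefore do not relate to the new compound in the same way, and only the comparison with the 4-ethylphenyl compound separates it from them. Methoxy in place of acetamido on the same phenyl ring gives a number 14 percentage points higher from compound 1 to compound 4 (beyond the scatter) and is the first comparison of two groups at this ring site with the rest of the compound held constant, so a 2-substituted phenyl does not by itself fix the number at the level of compound 1.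

The compounds shown leave open how a 4-methoxyphenyl or a 2-aminophenyl group would read here, and so whether these steps follow the substituent itself or its place on the phenyl ring. Nothing at hand gives a reason for any of these steps.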